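Trimethoxyphenyl variation on the heteroaryl ring of compound 2

This account rests on a few compounds, and the source may have more. Where it says the series, first, only, none or still open, it means among the compounds named here.

Measured so far:
compound 1 `COc1cc(/C=C/C(=O)c2cccc(-n3cc(-c4ccccc4)[nH]c3=O)c2)ccc1O`, 1850 nM
compound 2 `COc1cc(/C=C/C(=O)c2cccc(-n3cc(-c4ccccc4)[nH]c3=O)c2)cc(OC)c1OC`, 1740 nM

Two compounds have been run in a functional assay on SK-MEL-28 cells (Homo sapiens) for inhibition; a higher number here means a weaker inhibitor of growth, a lower number a stronger inhibitor of growth. In this assay compound 1 gives 1850 nM, and compound 2 gives 1740 nM. Compound 2 has the lowest of the two numbers, but its gap to compound 1 is within the scatter, so no order between the two can be read from these values.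

Compound 3 `COc1cc(/C=C/C(=O)c2cccc(-n3cc(-c4cc(OC)c(OC)c(OC)c4)[nH]c3=O)c2)cc(OC)c1OC` is not yet measured. It differs from compound 2 in one place: 3,4,5-trimethoxyphenyl in place of phenyl on an aromatic carbon. For the measured compounds named here, no pair of measured compounds shows what this change does in this assay. Given that the only measured variation, the change from compound 1 to compound 2, left the number essentially unchanged, the step from compound 2 to compound 3 is expected to be small, with a slight lean toward a lower number, and is estimated as a 1.5-fold lower number from compound 2 to compound 3 (0.16 log units; within the scatter). Compound 3 is therefore expected to give about 1200 nM in this assay, with a range from 450 nM to 3500 nM.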

Compound 3, concentration for 50% growth inhibition: 1610 nM
Estimate against measurement, compound 3: 1.3-fold (0.13 log units) below, within the range that was stated.
By their numbers in this assay, from the lowest: compounds 3, 2 and 1 (each within the scatter of the next).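

In this assay, for the compounds shown here, 3,4,5-trimethoxyphenyl in place of phenyl on this aromatic carbon gives a 1.1-fold lower number from compound 2 to compound 3 (0.03 log units; within the scatter), the first reading at this position. A group of 12 heavy atoms, with 3 hydrogen-bond acceptors, thus stands here in place of one of 6 heavy atoms with none, and the difference stays within the scatter. No measurement available on these compounds offers an explanation for this result.

From the compounds shown here alone, it remains open whether an amine, a carboxylic acid or a longer chain on this aromatic carbon would give a number beyond the scatter from that of compound 2. Also open, going by these compounds, is whether 3,4,5-trimethoxyphenyl at this position would give a similar step on the core of compound 1.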